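Replacing methoxycarbonyl with methyl on a weak compound

The source may hold more compounds than are shown below. What is called first, only, known or untested is meant among the compounds shown, and "the series" means these compounds.

In a functional assay on KYSE-450 cells (Homo sapiens) for inhibition, read by MTT assay, with a stated time of 48 h (a higher number here means a weaker inhibitor, a lower number a stronger inhibitor), compound 1 `COC(=O)c1cc(CNc2cc(OC)c(OC)c(OC)c2)ccc1OC` gives 41100 nM as its half-maximal inhibitory concentration. Going by the values given here, that puts it at the weak end of the numbers so far, level within the scatter with compound 3 `COc1ccc(N(Cc2cc(OC)c(OC)c(OC)c2)C(=O)CN=[N+]=[N-])cc1O` at 26100 nM and far from compound 2 `COc1ccc(CN(C(=O)CCl)c2cc(OC)c(OC)c(OC)c2)cc1O` at 210 nM on the strong side.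

Compound 4 `COc1ccc(CNc2cc(OC)c(OC)c(OC)c2)cc1C` differs from compound 1 in a single place: methyl in place of methoxycarbonyl on an aromatic carbon and the rest of the structure stays the same. Compounds 2 and 3 each differ from compound 1 in more than one place, so no measured single change is available as a guide. With nothing to point to a large effect, I expect a small move towards a lower number, probably not beyond the scatter. The estimated change is a 1.6-fold lower number from compound 1 to compound 4 (0.22 log units; within the scatter) as a modest step. In this assay the expected value for compound 4 is 25000 nM with a likely range from 7000 nM to 80000 nM as its estimated bounds.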

Compound 4, half-maximal inhibitory concentration: 73800 nM
Compound 4: middle estimate off by 3.0-fold (0.47 log units), on the low side; the range from low to high includes it.
By their numbers in this assay, from the lowest: compound 2; then compounds 3, 1 and 4 (each within the scatter of the next, the first and the last beyond it).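

Swapping methoxycarbonyl for methyl on this aromatic carbon, ortho to a methoxy group, gives in this assay a 1.8-fold higher number from compound 1 to compound 4 (0.25 log units; within the scatter). The exchange is a large one on paper: a group of four heavy atoms with a double bond and two hydrogen-bond acceptors gives way to a single carbon with no acceptors, yet the read-out stays within the scatter, so at this level of activity the methoxycarbonyl group is not shown to matter here. Nothing available explains this result.

From the compounds shown here alone, whether any group at this position can move the number beyond the scatter remains open, for example a carboxylic acid, an amine or a longer chain. Also open, going by these compounds, is whether the same swap would stay within the scatter on a much stronger compound.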